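Shuffling the Hydroxyalkyl Ester Side Chain toward Compound 3

The compounds below may be only part of what the source reports. "The series", "measured", "known", "first", "only" and "open" are said of these compounds alone.

Two esters built on one shared core have been measured for cytotoxicity. Compound 1 `C=C1C(=O)O[C@@H]2[C@H]3O[C@]3(C)CC/C=C(\C)[C@@H](OC(=O)C(C)(O)CC)C[C@@H]12` carries a 1-hydroxy-1-methylpropyl group on the carbonyl carbon of the ester, and in a functional assay on HRT-18 cells (Homo sapiens) for cytotoxicity, read by MTT assay, with a stated time of 48 h (a lower number here means a stronger inhibitor, a higher number a weaker inhibitor), compound 1 gives 8.75 ug/mL. Compound 2 `C=C1C(=O)O[C@@H]2[C@H]3O[C@]3(C)CC/C=C(\C)[C@@H](OC(=O)CC(C)(C)O)C[C@@H]12` carries 2-hydroxy-2-methylpropyl at that carbonyl carbon instead, and in this assay compound 2 gives 14.9 ug/mL. Compound 2 thus holds the higher of the two numbers, with compound 1 nearest, but the step of a 1.7-fold higher number from compound 1 to compound 2 (0.23 log units; within the scatter) lies within the scatter, so the two cannot be ranked against each other.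

Compound 3 `C=C1C(=O)O[C@@H]2[C@H]3O[C@]3(C)CC/C=C(\C)[C@@H](OC(=O)C(C)C(C)O)C[C@@H]12` has not been measured. It differs from compound 2 as follows: 2-hydroxy-1-methylpropyl in place of 2-hydroxy-2-methylpropyl on a carbonyl carbon. Among the compounds with values here, the only measured step that bears on this change is a 1.7-fold higher number from compound 1 to compound 2 (0.23 log units; within the scatter), which likewise rearranged the same atoms of the hydroxyalkyl side chain on the carbonyl carbon without moving beyond the scatter. The step from compound 2 to compound 3 is therefore expected to be a 1.2-fold lower number from compound 2 to compound 3 (0.09 log units; within the scatter), none beyond the scatter. Compound 3 is estimated at 12 ug/mL, within a range of 6 ug/mL to 24 ug/mL.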

Compound 3, half-maximal inhibitory concentration: 13.4 ug/mL
Estimate against measurement, compound 3: 1.1-fold (0.05 log units) below; low and high end bracket the measured number.
By their numbers in this assay, from the lowest: compounds 1, 3 and 2 (each within the scatter of the next).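

With 2-hydroxy-1-methylpropyl on the carbonyl carbon, this assay now covers a third arrangement of the same side-chain atoms, and the result reads as a 1.1-fold lower number from compound 2 to compound 3 (0.05 log units; within the scatter) and as a 1.5-fold higher number from compound 1 to compound 3 (0.19 log units; within the scatter) when set against the first ester. Where the earlier pair offered a single step within the scatter, all three pairs among 1-hydroxy-1-methylpropyl, 2-hydroxy-2-methylpropyl and 2-hydroxy-1-methylpropyl now lie within it, so this rearrangement of the same atoms on the carbonyl carbon does not separate compound 1, compound 2 and compound 3 in this cell assay, and none of them can be ranked against another. Nothing available accounts for this lack of separation or says what the side chain does in the cells.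

Because the three side chains hold the same atoms, the compounds shown leave open how the number would respond if an amine or a carboxylic acid took the place of the hydroxyl, or if a longer chain sat on the carbonyl carbon. Going by these compounds, whether a plain butyl chain with no hydroxyl would stay within the same scatter also remains open.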